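Indolyl replacement for ethylpyrazole: clearance expectation

The compounds below may be only part of what the source reports. "The series", "measured", "known", "first", "only" and "open" are said of these compounds alone.

Compound 1 `Cn1cc(-c2cc(C(O)(C(F)(F)F)C(F)(F)F)cnc2N2CCN(S(=O)(=O)c3ccc(N)nc3)CC2)cn1` gives 19 mL.min-1.g-1 in an ADME assay (liver) for metabolic stability, with Liver microsome (Homo sapiens) as the target, using microsomes and NADPH, with a stated time of 30 min, tested at 1 uM; a lower number here means slower removal, a higher number faster removal of the compound.
Compound 2 `CCn1cc(-c2cc(C(O)(C(F)(F)F)C(F)(F)F)cnc2N2CCN(S(=O)(=O)c3ccc(N)nc3)CC2)cn1` gives 20 mL.min-1.g-1 in this assay.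
Compound 3 `CS(=O)(=O)Nc1cccc(-c2cc(C(O)(C(F)(F)F)C(F)(F)F)cnc2N2CCN(S(=O)(=O)c3ccc(N)nc3)CC2)c1` gives 40 mL.min-1.g-1 in this assay.

Compound 2 sits second highest of the three numbers, nearest to compound 1 and furthest from compound 3, both gaps within the scatter. Compound 4 `Nc1ccc(S(=O)(=O)N2CCN(c3ncc(C(O)(C(F)(F)F)C(F)(F)F)cc3-c3cc4ccccc4[nH]3)CC2)cn1` differs from compound 2 by 1H-indol-2-yl in place of 1-ethyl-1H-pyrazol-4-yl on an aromatic carbon. The nearest precedents are the aryl-for-pyrazole replacements: a 2.0-fold higher number from compound 2 to compound 3 (0.30 log units; within the scatter) and a 2.1-fold higher number from compound 1 to compound 3 (0.32 log units; beyond the scatter). On that basis a modest rise in this assay is expected, of about a 2.0-fold higher number from compound 2 to compound 4 (0.30 log units; within the scatter). Within the data shown here, compound 4 is therefore estimated at 40 mL.min-1.g-1, with a range from 20 mL.min-1.g-1 to 80 mL.min-1.g-1, because the only measured change of this kind, a 2.0-fold higher number from compound 2 to compound 3 (0.30 log units; within the scatter), was itself modest.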

Compound 4, intrinsic clearance in microsomes: < 14 mL.min-1.g-1
Compound 4 ended at the assay's limit (the forecaster's own chance of this, stated with the estimate: 5%); middle value at least 2.8-fold (0.45 log units) from the limit.
By their numbers in this assay, from the lowest: compounds 1, 2 and 3 (each within the scatter of the next, the first and the last beyond it). At a limit, below all of these: compound 4.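

Compound 4 is recorded as a limit, not a number: the limit of < 14 mL.min-1.g-1 in this assay, at which 1 of the 4 values shown sits. Compound 3 alone had shown an aryl group at this aromatic carbon, and 1H-indol-2-yl shows that a fused aromatic group there can go with a lower number, with an at least 2.8-fold lower number from compound 3 to compound 4 (0.45 log units; beyond the scatter). Against the pyrazoles, only floors can be read, with an at least 1.4-fold lower number from compound 2 to compound 4 (0.15 log units; that floor lies within the scatter) and an at least 1.3-fold lower number from compound 1 to compound 4 (0.13 log units; that floor lies within the scatter).

On these data alone, the true size of those two gaps stays open. Also open, as far as these compounds go, is whether an amine or a carboxylic acid on the 1H-indol-2-yl group would keep the number at the limit.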